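Swapping an ethyl for a vinyl on a weak cytidine-like inhibitor

This account rests on a few compounds, and the source may have more. Where it says the series, first, only, none or still open, it means among the compounds named here.

Compound 1 `CC[C@@]1(O)[C@@H](CO)O[C@@H](n2ccc(N)nc2=O)[C@@H]1O`: 258000 nM
Compound 2 `C#C[C@]1(O)[C@H](O)[C@@H](CO)O[C@H]1n1ccc(N)nc1=O`: > 350000 nM
Compound 3 `O=c1ccn([C@@H]2O[C@H](CO)[C@](O)(C3CC3)[C@H]2O)c(=O)[nH]1`: > 350000 nM

In a functional assay on KB cells (Homo sapiens), read by MTT assay (a lower number here means a stronger inhibitor, a higher number a weaker inhibitor), compound 1 gives 258000 nM, and it is the only one of the three measured compounds for which this assay returns a number at all. For compound 2 the value > 350000 nM is a limit of the assay, not a number. For compound 3 the value > 350000 nM is likewise a limit of the assay. So compound 1 stands on its own as the one measured compound with a real reading, while the other two sit at the limit of > 350000 nM in this assay, at which 2 of the 3 values shown sit.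

Compound 4 `C=C[C@@]1(O)[C@@H](CO)O[C@@H](n2ccc(N)nc2=O)[C@@H]1O` has not yet been measured. It differs from compound 1 by vinyl in place of ethyl on a saturated ring carbon. For the measured compounds named here, the change keeps the size of the group and its lack of donors and acceptors, and no measured step with a similar change exists here to guide a direction. The expectation is therefore a step of a 1.1-fold higher number from compound 1 to compound 4 (0.04 log units; within the scatter), which is no step beyond the usual scatter. Compound 4 is expected to give about 280000 nM, within roughly 120000 nM to 600000 nM, with a fair chance that only a limit is reported.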

Compound 4, half-maximal inhibitory concentration: 74300 nM
The estimate for compound 4 lay 3.8-fold (0.58 log units) above the measured number, outside the stated range (below it).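

In this assay, replacing ethyl with vinyl on the saturated ring carbon gives a 3.5-fold lower number from compound 1 to compound 4 (0.54 log units; beyond the scatter), a modest step but one beyond the usual scatter. This is the first pair shown that differs in one place, and it indicates that the group at this position can change the reading even when the swap is small: ethyl and vinyl have the same count of heavy atoms, and neither has hydrogen-bond donors or acceptors, so the counted difference is the double bond of the vinyl. No measured property of either group is given here, so the data name no cause for this step.

Steps involving compound 2 and compound 3 cannot be read, as each of these compounds gives only a limit of the assay. As far as these compounds go, it remains open whether a longer chain such as propyl, or an aminomethyl group, at the same ring carbon would give a lower or a higher number than the vinyl of compound 4.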